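Coumarin pyrazoline: swapping an aryl amide for an aminopiperidine

The compounds below may be only part of what the source reports. "The series", "measured", "known", "first", "only" and "open" are said of these compounds alone.

Compound 3 `O=C(c1ccccc1Cl)N1N=C(c2cc3ccccc3oc2=O)CC1c1ccccc1` was tested in a functional assay on MGC-803 cells (Homo sapiens) for cytotoxicity, read by MTT assay, with a stated time of 48 h (on this read-out higher numbers stand for weaker inhibition and lower numbers for stronger inhibition), where compound 3 gives 6640 nM. Among the three numbers measured, compound 3 sits between the others: compound 2 `CC(=O)Oc1ccccc1C1CC(C)=NN1C(=O)CN1CCC(C(C)=O)CC1` gives 4120 nM and compound 1 `CC1=NN(C(=O)CN2CCC(c3ccccc3)CC2)C(c2ccccc2O)C1` gives 12300 nM, and both gaps to compound 3 lie within the usual scatter. Compound 4 `CCN(CC)C1CCN(CC(=O)N2N=C(c3cc4ccccc4oc3=O)CC2c2ccccc2)CC1` is not yet measured. It differs from compound 3 by (4-(diethylamino)piperidin-1-yl)methyl in place of 2-chlorophenyl on a carbonyl carbon. Compounds 1 and 2 already carry a piperidinylmethyl group on this carbonyl, and their numbers are no further from compound 3 than the scatter allows, so no step beyond the scatter is expected here. The estimate for compound 4 is 4000 nM, with a range of 1200 nM to 13000 nM, meaning an expected step of a 1.7-fold lower number from compound 3 to compound 4 (0.22 log units; within the scatter).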

Compound 4, half-maximal inhibitory concentration: 32400 nM
Beside the measured number, compound 4's estimate is 8.1-fold (0.91 log units) below it; measured number outside the range, above it.
By their numbers in this assay, from the lowest: compounds 2, 3 and 1 (each within the scatter of the next, the first and the last beyond it); then compound 4.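

In this assay, among the compounds shown here, placing (4-(diethylamino)piperidin-1-yl)methyl instead of 2-chlorophenyl on this carbonyl carbon gives a 4.9-fold higher number from compound 3 to compound 4 (0.69 log units; beyond the scatter), the first measured change at this position on a shared core. The position therefore responds to what it carries, and this exchange weakens inhibition. Nothing available explains why.

From the compounds shown here alone, it remains open whether the diethylamino group or the loss of the 2-chlorophenyl ring accounts for the step. An unsubstituted piperidine or a morpholine in the same place could help separate the two.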